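The compounds below may be only part of what the source reports. "The series", "measured", "known", "first", "only" and "open" are said of these compounds alone.

Of the compounds shown here, three built on a shared core have been measured in a functional assay on MDA-MB-435 cells (Homo sapiens) for inhibition, read by sulforhodamine B assay, with a stated time of 48 h; a lower number here means a stronger inhibitor of growth, a higher number a weaker inhibitor of growth. Compound 1 `COc1cc(-c2nn(-c3cccc(NC(=O)c4ccc(Cl)c(C(F)(F)F)c4)c3)cc2-c2ccncc2)ccc1Cl` gives 1740 nM. Compound 3 `COc1cc(-c2nn(-c3cccc(NC(=O)Nc4ccc(Cl)c(C(F)(F)F)c4)c3)cc2-c2ccncc2)ccc1Cl` differs from compound 1 by carrying a (4-chloro-3-(trifluoromethyl)phenyl)amino in place of 4-chloro-3-(trifluoromethyl)phenyl on a carbonyl carbon. In this assay compound 3 gives 1690 nM; that change is a 1.0-fold lower number from compound 1 to compound 3 (0.01 log units; within the scatter), so it left the result essentially unchanged. Compound 2 `O=C(Nc1cccc(-n2cc(-c3ccncc3)c(-c3ccc(Cl)c(O)c3)n2)c1)Nc1cc(C(F)(F)F)cc(C(F)(F)F)c1` gives 2590 nM. Its number lies within the usual scatter of both compound 1 and compound 3, so on these three results the compounds cannot be told apart.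

Compound 4 `O=C(Nc1cccc(-n2cc(-c3ccncc3)c(-c3ccc(Cl)c(O)c3)n2)c1)Nc1cccc(C(F)(F)F)c1` has not yet been measured. It differs from compound 2 in one place: hydrogen in place of trifluoromethyl on an aromatic carbon. Going by the values given here, no measured step here tests this kind of change; the only step on record, between compound 1 and compound 3, concerns a different part of the molecule and was itself flat. With nothing pointing to a gain or a loss, the expectation is a step of a 1.0-fold higher number from compound 2 to compound 4 (0.00 log units; within the scatter), that is, nothing beyond the scatter. The estimate for compound 4 in this assay is therefore 2600 nM, with a likely range from 1200 nM to 5600 nM.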

Compound 4, concentration for total growth inhibition: 12600 nM
The estimate for compound 4 lay 4.8-fold (0.69 log units) below the measured number, and the stated range ends below it.
By their numbers in this assay, from the lowest: compounds 3, 1 and 2 (each within the scatter of the next); then compound 4.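

In this assay, putting hydrogen in place of trifluoromethyl on this aromatic carbon, which sits meta to a trifluoromethyl group, gives a 4.9-fold higher number from compound 2 to compound 4 (0.69 log units; beyond the scatter), a modest step that is still clear of the usual scatter. It is the first change here to move the number that far: the only earlier step, a 1.0-fold lower number from compound 1 to compound 3 (0.01 log units; within the scatter), lies in a different part of the molecule and stayed within the scatter, so this position is the first one shown to matter, with the trifluoromethyl-bearing compound 2 being the stronger inhibitor of growth in this pair. Nothing available here explains why the number rises.

This single pair cannot show whether the trifluoromethyl group itself is needed on this carbon or whether another group would serve equally well, and a methyl group, a chlorine atom or an amine there would begin to answer that. On these data alone, it also remains open whether the same step would appear in compounds carrying a methoxy group in place of the hydroxyl group, as compound 1 and compound 3 do.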